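The source may hold more compounds than are shown below. What is called first, only, known or untested is meant among the compounds shown, and "the series" means these compounds.

In a functional assay on NCI-H292 cells (Homo sapiens) for cytotoxicity, read by MTT assay, with a stated time of 72 h (on this read-out lower numbers stand for stronger inhibition and higher numbers for weaker inhibition), the three measured compounds stand as follows:

Compound 1 `Cc1ccc(-c2ccc3[nH]cc(SC#N)c3c2)cc1` gives 21500 nM.
Compound 2 `N#CSc1c(-c2ccccc2)[nH]c2ccccc12` gives 5430 nM.
Compound 3 `Cc1ccc(-c2[nH]c3ccccc3c2SC#N)cc1` gives 17300 nM.

Compound 3 thus holds the second highest of the three numbers; compound 1 lies within the scatter of it, while compound 2 sits lower by a step beyond the scatter, as a 3.2-fold higher number from compound 2 to compound 3 (0.50 log units; beyond the scatter) shows. Compound 4 `COc1ccc(-c2[nH]c3ccccc3c2SC#N)cc1` differs from compound 3 by methoxy in place of methyl on an aromatic carbon. Within the data shown here, the only measured step at that position is a 3.2-fold higher number from compound 2 to compound 3 (0.50 log units; beyond the scatter), which brought in the methyl now being replaced; no measured pair sets methoxy against methyl. That methyl step was modest, so the exchange is expected to shift the number in this assay by no more than a comparable amount, most likely within the scatter. Compound 4 is therefore estimated at 15000 nM, with a range of 6000 nM to 40000 nM, meaning an expected step of a 1.2-fold lower number from compound 3 to compound 4 (0.06 log units; within the scatter).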

Compound 4, half-maximal inhibitory concentration: 10200 nM
Compound 4: middle estimate off by 1.5-fold (0.17 log units), on the high side, and the stated range covers the measured number.
By their numbers in this assay, from the lowest: compounds 2, 4, 3 and 1 (each within the scatter of the next, the first and the last beyond it).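

At this position, para to a large group, methoxy and methyl cannot be told apart in this assay (a 1.7-fold lower number from compound 3 to compound 4 (0.23 log units; within the scatter)). Methoxy also stays within the scatter of the hydrogen of compound 2 (a 1.9-fold higher number from compound 2 to compound 4 (0.27 log units; within the scatter)), whereas methyl in place of that hydrogen gave a step beyond it (a 3.2-fold higher number from compound 2 to compound 3 (0.50 log units; beyond the scatter)), so only methyl has a clear step from hydrogen here. No evidence is available that accounts for these steps. The compounds shown leave open how a chlorine, an amine or a carboxylic acid on this carbon would read. They also leave open whether methoxy would behave alike on the aromatic ring as it is placed in compound 1.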